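Arylamino replacement on the shared core: compound 4

A few compounds are considered here, and "the series" means these few. Any claim that something is new, unique, unknown or untested is made for them only; others in the source may bear on it.

Compound 1 `COc1cc(C(=O)c2sc3ccccc3c2-c2ccc(Cl)cc2)cc(OC)c1OC` carries a 4-chlorophenyl group on the shared core. For the measured compounds named here, in a functional assay on HeLa cells (Homo sapiens) for antiproliferative activity, read by MTT assay, with a stated time of 72 h (a higher number here means a weaker inhibitor, a lower number a stronger inhibitor), compound 1 gives 5200 nM, the second highest of the three numbers so far. Compound 2 `COc1ccc(-c2c(C(=O)c3cc(OC)c(OC)c(OC)c3)sc3ccccc23)c(OC)c1` gives 3900 nM, and compound 3 `COc1ccc(Nc2c(C(=O)c3cc(OC)c(OC)c(OC)c3)sc3ccccc23)cc1` gives 7700 nM. The three steps among them are a 1.3-fold lower number from compound 1 to compound 2 (0.12 log units; within the scatter), a 1.5-fold higher number from compound 1 to compound 3 (0.17 log units; within the scatter) and a 2.0-fold higher number from compound 2 to compound 3 (0.30 log units; within the scatter); none reaches beyond the scatter, so the three compounds cannot be ordered on these numbers.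

Compound 4 `CCOc1ccc(Nc2c(C(=O)c3cc(OC)c(OC)c(OC)c3)sc3ccccc23)cc1` differs from compound 1 as follows: (4-ethoxyphenyl)amino in place of 4-chlorophenyl on an aromatic carbon. Compound 3 bears the closely related (4-methoxyphenyl)amino group at the same place. The step that bears most directly on compound 4 is a 1.5-fold higher number from compound 1 to compound 3 (0.17 log units; within the scatter). That step stayed within the scatter, so no change beyond the scatter is expected for compound 4 either, though the number may lean somewhat higher, as it did for compound 3. For compound 4 a value of 7500 nM is estimated, with a range of 3500 nM to 16000 nM. This estimate corresponds to an expected step of a 1.4-fold higher number from compound 1 to compound 4 (0.16 log units; within the scatter).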

Compound 4, half-maximal inhibitory concentration: 700 nM
The estimate for compound 4 lay 11-fold (1.03 log units) above the measured number; measured number outside the range, below it.
By their numbers in this assay, from the lowest: compound 4; then compounds 2, 1 and 3 (each within the scatter of the next).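

In this assay, for the compounds shown here, the single change of methyl in place of hydrogen on a saturated chain carbon bound to an oxygen on an aromatic ring gives an 11-fold lower number from compound 3 to compound 4 (1.04 log units; beyond the scatter), so this position responds to a small change at the end of the arylamino group, which the earlier steps, all within the scatter, did not show. The (4-ethoxyphenyl)amino group also separates from the directly attached aryl groups, with a 7.4-fold lower number from compound 1 to compound 4 (0.87 log units; beyond the scatter) and a 5.6-fold lower number from compound 2 to compound 4 (0.75 log units; beyond the scatter), yet compound 3 shows that an arylamino group alone does not produce this separation. Nothing available explains the step.

As far as these compounds go, it remains open whether a longer chain, such as propoxy or butoxy, in place of the ethoxy group extends or reverses the step. Also open, from the compounds shown here alone, is whether a 4-ethoxyphenyl group attached directly to the shared core, without the amino nitrogen, would behave like compound 4.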